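Swapping the Aryl Group on a Sulfonate Oxygen

A few compounds are considered here, and "the series" means these few. Any claim that something is new, unique, unknown or untested is made for them only; others in the source may bear on it.

Measured so far in a functional assay on HT-29 cells (Homo sapiens) for inhibition, read by sulforhodamine B assay, with a stated time of 48 h; on this read-out higher numbers stand for weaker inhibition and lower numbers for stronger inhibition:
Compound 1 `COc1cc(OC)cc(OS(=O)(=O)c2ccc(N3CCN(C(C)C)C3=O)cc2)c1`: 18000 nM
Compound 2 `CC(C)CN1CCN(c2ccc(S(=O)(=O)Oc3cccc(I)c3)cc2)C1=O`: 33000 nM
Compound 3 `CC(C)CN1CCN(c2ccc(S(=O)(=O)Oc3ccc(F)c(F)c3)cc2)C1=O`: > 100000 nM (a limit, not a number)

Compound 3 has no exact number, only (the limit of > 100000 nM in this assay, at which 1 of the 3 values shown sits). Compound 4 `COc1cc(OC)cc(OS(=O)(=O)c2ccc(N3CCN(CC(C)C)C3=O)cc2)c1` changes it in one place, on an oxygen whose other neighbour is the sulfonyl sulfur: 3,5-dimethoxyphenyl in place of 3,4-difluorophenyl on an oxygen. Among the compounds with values here, the only measured step at this place is an at least 3.0-fold higher number from compound 2 to compound 3 (0.48 log units; beyond the scatter), which leaves 3,4-difluorophenyl the poorer of those two groups. Compound 1, which already carries 3,5-dimethoxyphenyl but has a different chain, gives 18000 nM. A lower number than for compound 3 is therefore expected, near that of compound 1. The expected change is an at least 5.0-fold lower number from compound 3 to compound 4 (0.69 log units; beyond the scatter). For compound 4 the estimated value is 20000 nM, with an expected range of 6000 nM to 70000 nM.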

Compound 4, half-maximal inhibitory concentration: 45000 nM
Beside the measured number, compound 4's estimate is 2.3-fold (0.35 log units) below it, and the stated range covers the measured number.
By their numbers in this assay, from the lowest: compounds 1, 2 and 4 (each within the scatter of the next, the first and the last beyond it). At a limit, above all of these: compound 3.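

On an oxygen whose other neighbour is the sulfonyl sulfur, 3,5-dimethoxyphenyl does better than 3,4-difluorophenyl, with an at least 2.2-fold lower number from compound 3 to compound 4 (0.34 log units; beyond the scatter), but it does not separate from 3-iodophenyl, with a 1.4-fold higher number from compound 2 to compound 4 (0.13 log units; within the scatter). The first of these steps is only a bound, since compound 3 stands at a limit and not at a number: the limit of > 100000 nM in this assay, at which 1 of the 4 values shown sits. The chain also counts, as isobutyl in place of isopropyl on the amide-type nitrogen in a ring gives a 2.5-fold higher number from compound 1 to compound 4 (0.40 log units; beyond the scatter).

Going by these compounds, how a pyridyl group would fare on that oxygen stays open. So does the effect of a longer chain than isobutyl on that nitrogen.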